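Benzyl for Phenyl on the Hydrazine Nitrogen

The compounds below may be only part of what the source reports. "The series", "measured", "known", "first", "only" and "open" are said of these compounds alone.

Compound 1 `Cc1ccccc1-c1nnc(N(N)C(C)C)s1`: 49 mg/kg
Compound 2 `Cc1ccccc1-c1nnc(N(N)c2ccccc2)s1`: > 100 mg/kg

In a functional assay on the whole organism with Mus musculus as the target, with a stated time of 1 h (on this read-out higher numbers stand for an effect only at larger amounts of compound and lower numbers for an effect already at smaller amounts), compound 2 stands only at a limit of the assay, > 100 mg/kg, with no number of its own. Compound 3 `Cc1ccccc1-c1nnc(N(N)Cc2ccccc2)s1` differs from it as follows: benzyl in place of phenyl on a nitrogen on an aromatic ring. Going by the values given here, no measured step covers this change directly; the nearest is an at least 2.0-fold higher number from compound 1 to compound 2 (0.30 log units; that floor lies within the scatter), which ends at the same limit (the limit of > 100 mg/kg in this assay, at which 1 of the 2 values shown sits). Since compound 2 has no number, no step size in this assay can be derived for compound 3, and a number near or above the limit remains possible. Compound 3 is estimated at 80 mg/kg (range 30 mg/kg to 200 mg/kg). The expected step is an at least 1.2-fold lower number from compound 2 to compound 3 (0.09 log units; that floor lies within the scatter).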

Compound 3, dose for half-maximal effect: 44 mg/kg
The estimate for compound 3 lay 1.8-fold (0.26 log units) above the measured number; the range from low to high includes it.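

In this assay, this nitrogen tolerates an aromatic ring when it is carried as benzyl rather than as phenyl, with an at least 2.2-fold lower number from compound 2 to compound 3 (0.35 log units; beyond the scatter). Benzyl and isopropyl cannot be told apart here, with a 1.1-fold lower number from compound 1 to compound 3 (0.05 log units; within the scatter), so among the three groups only phenyl leaves a compound without a number of its own. That step is a floor and not a full size: the limit of > 100 mg/kg in this assay, at which 1 of the 3 values shown sits.

On these data alone, what stays open is whether a longer chain such as phenethyl would keep this level of effect. Also open, as far as these compounds go, is how an amine or a carboxylic acid on the benzyl ring would fare.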